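Halogen swap on the benzoyl arm of a thiazole acylurea

A few compounds are considered here, and "the series" means these few. Any claim that something is new, unique, unknown or untested is made for them only; others in the source may bear on it.

Compound 1 `CN(C(=O)NC(=O)c1ccc(Cl)cc1Cl)c1nc(C(F)(F)F)c(C(=O)N/N=C/c2ccc(C(F)(F)F)cc2)s1`: 8.42 ug/mL
Compound 2 `CN(C(=O)NC(=O)c1cccc([N+](=O)[O-])c1)c1nc(C(F)(F)F)c(C(=O)N/N=C/c2ccccc2C(F)(F)F)s1`: 4.73 ug/mL

Of the compounds shown here, two have been tested in a functional assay on MCF7 cells (Homo sapiens) for inhibition, read by MTT assay, with a stated time of 72 h; a lower number here means a stronger inhibitor, a higher number a weaker inhibitor. Compound 1 gives 8.42 ug/mL, the highest of the two numbers; its nearest neighbour, compound 2, gives 4.73 ug/mL, and the two values fall within the usual scatter of each other, so nothing can be said about an order between them.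

Compound 3 `CN(C(=O)NC(=O)c1ccc(F)c(F)c1)c1nc(C(F)(F)F)c(C(=O)N/N=C/c2ccc(C(F)(F)F)cc2)s1` has not yet been measured. It differs from compound 1 at one place:

3,4-difluorophenyl in place of 2,4-dichlorophenyl on a carbonyl carbon

For the measured compounds named here, no pair of measured compounds in this set differs only at that place, so there is no measured step to lean on. The change exchanges one halogenated aromatic ring for another of equal size, and the rest of the molecule is unchanged. On that basis the step from compound 1 to compound 3 is expected to be small, a 1.2-fold higher number from compound 1 to compound 3 (0.07 log units; within the scatter), leaning if anything toward a somewhat higher number. Compound 3 is therefore estimated at 10 ug/mL, within a range from 4 ug/mL to 25 ug/mL.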

Compound 3, half-maximal inhibitory concentration: 5.93 ug/mL
For compound 3 the middle estimate is 1.7-fold (0.23 log units) above the measured one; measured number inside the range.
By their numbers in this assay, from the lowest: compounds 2, 3 and 1 (each within the scatter of the next).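

In this assay the series now has its first measured step at this carbonyl carbon: a 1.4-fold lower number from compound 1 to compound 3 (0.15 log units; within the scatter) on exchanging 2,4-dichlorophenyl for 3,4-difluorophenyl. Within the usual scatter, the assay does not tell these two halogenated rings apart, so this place accepts either one with no readable effect on the number. The halogen and its placement on the ring change together in this step, however, so the result cannot assign anything to either alone.

The compounds shown leave open whether this insensitivity would hold for a plain phenyl ring, or for a ring carrying an amine or a carboxylic acid at this same carbonyl carbon. No measurement is available that would explain the values of these compounds.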